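The compounds below may be only part of what the source reports. "The series", "measured", "known", "first", "only" and "open" are said of these compounds alone.

Measured compounds:
compound 1 `COc1cccc(/C=C/C(=O)c2ccc(OCCn3cc(CN4C(=O)/C=C/C(C)(C)C/C=C(\C)CC/C=C/4C)nn3)cc2O)c1` gives 0.89 ug/mL
compound 2 `COc1ccccc1/C=C/C(=O)c1ccc(OCCn2cc(CN3C(=O)/C=C/C(C)(C)C/C=C(\C)CC/C=C/3C)nn2)cc1O` gives 1.1 ug/mL
compound 3 `COc1cccc(/C=C/C(=O)c2ccc(OCCCN3C(=O)/C=C/C(C)(C)C/C=C(\C)CC/C=C/3C)cc2)c1` gives 1.1 ug/mL

All three were tested in a functional assay on P338 cells (Mus musculus) for antiproliferative activity; on this read-out higher numbers stand for weaker inhibition and lower numbers for stronger inhibition. Compound 1 and compound 2 share a core and differ by one change, (2-methoxyphenyl in place of 3-methoxyphenyl on a double-bonded chain carbon bound to a double-bonded chain carbon); the result was a 1.2-fold higher number from compound 1 to compound 2 (0.09 log units; within the scatter), so the two sit side by side. Compound 3 stands on a different core; how its core differs from that of compound 1 is not broken down here. In this assay compound 3 gives 1.1 ug/mL, which is level with compound 2 and close to compound 1, so the three measured numbers lie close together.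

Compound 4 `COc1ccccc1/C=C/C(=O)c1ccc(OCCCN2C(=O)/C=C/C(C)(C)C/C=C(\C)CC/C=C/2C)cc1` has not yet been measured. It is made from compound 3 by the same change, (2-methoxyphenyl in place of 3-methoxyphenyl on a double-bonded chain carbon bound to a double-bonded chain carbon), and the place of the change is described in the same words. Because the earlier step of this change gave a 1.2-fold higher number from compound 1 to compound 2 (0.09 log units; within the scatter), the step from compound 3 to compound 4 is expected to be small as well, about a 1.2-fold higher number from compound 3 to compound 4 (0.07 log units; within the scatter). On that basis compound 4 is estimated at 1.3 ug/mL in this assay, with a likely range from 0.6 ug/mL to 2.8 ug/mL.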

Compound 4, half-maximal inhibitory concentration: 0.83 ug/mL
Compound 4: middle estimate off by 1.6-fold (0.19 log units), on the high side; low and high end bracket the measured number.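

In this assay the swap of 3-methoxyphenyl for 2-methoxyphenyl on the core of compound 3 gives a 1.3-fold lower number from compound 3 to compound 4 (0.12 log units; within the scatter) and so, like the earlier step, leaves the two compounds level within the normal spread of repeated measurements. This shows that in these two pairs the change has no readable effect on either core, but it does not establish a size or direction for the change, and two pairs cannot show how it would behave on any other core. Set side by side, the two steps point in opposite directions, yet they cannot be told apart: the same change on two cores in this assay, a 1.2-fold higher number (0.09 log units; within the scatter) from compound 1 to compound 2 and a 1.3-fold lower number (0.12 log units; within the scatter) from compound 3 to compound 4, 1.6-fold (0.21 log units) apart, within the scatter of two such steps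

The compounds shown leave open whether a phenyl ring carrying an amine or a carboxylic acid in place of the methoxy group would move the number beyond the scatter. They also leave open whether a longer chain in the linker of compound 3 would alter the antiproliferative result.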